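The compounds below may be only part of what the source reports. "The series", "measured", "known", "first", "only" and "open" are said of these compounds alone.

Three compounds have been measured in an ADME assay on PANC-1 cells (Homo sapiens) for cytotoxicity, read by sulforhodamine B assay, with a stated time of 48 h, tested at 10 uM; a higher number here means more inhibition at the concentration tested (going by the name of the read-out), a lower number less inhibition:

Compound 1, `COc1nc2ccc(Br)cc2cc1C(c1ccccc1)n1cc(-c2ccccc2F)nn1`, gives 14.7%.
Compound 2, `COc1nc2ccc(Br)cc2cc1C(c1ccccc1)n1cc(-c2cccc(F)c2)nn1`, gives 15.5%.
Compound 3, `CCCCCCc1cn(C(c2ccccc2)c2cc3cc(Br)ccc3nc2OC)nn1`, gives 6.08%.

Compound 3 carries the lowest of the three numbers, but the gap to compound 1, a number 8.6 percentage points lower from compound 1 to compound 3 (within the scatter), and the gap to compound 2, a number 9.4 percentage points lower from compound 2 to compound 3 (within the scatter), both sit within the scatter of this assay, so the three compounds cannot be told apart on these numbers. The step from compound 1 to compound 2, a number 0.8 percentage points higher from compound 1 to compound 2 (within the scatter), is likewise within the scatter.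

Compound 4, `CCCc1cn(C(c2ccccc2)c2cc3cc(Br)ccc3nc2OC)nn1`, differs from compound 3 in one place: hydrogen in place of propyl on a saturated chain carbon, three bonds along the chain from an aromatic carbon. For the measured compounds named here, no measured step shortens a chain in this way. The nearest comparisons are the two steps that exchange the hexyl chain for a fluorophenyl ring, a number 8.6 percentage points lower from compound 1 to compound 3 (within the scatter) and a number 9.4 percentage points lower from compound 2 to compound 3 (within the scatter), and both stay within the scatter. Because the much larger change at this position in a number 8.6 percentage points lower from compound 1 to compound 3 (within the scatter) moved the number only within the scatter, a trimming of the chain is expected to move it no further, and the expected step is a number 0.9 percentage points higher from compound 3 to compound 4 (within the scatter). Compound 4 is therefore estimated at 7%, with a range from 0% to 16%.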

Compound 4, a percentage reported as inhibition, at one concentration (the size of the read-out at that concentration, not a potency): 11.3%
The estimate for compound 4 lay 4.3 percentage points below the measured number; measured number inside the range.
By their numbers in this assay, from the lowest: compounds 3, 4, 1 and 2 (each within the scatter of the next).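

In this assay, for the compounds shown here, going from hexyl to propyl gives the first step that alters the length of the chain alone at this position (a number 5.2 percentage points higher from compound 3 to compound 4 (within the scatter)), so the two chains cannot be told apart. The propyl chain also cannot be told apart from either fluorophenyl ring, as the exchanges of ring for chain show (a number 4.2 percentage points lower from compound 2 to compound 4 (within the scatter)) and (a number 3.4 percentage points lower from compound 1 to compound 4 (within the scatter)). The earlier compounds shown here had set only the hexyl chain against the two rings, whereas these steps show that a shorter chain also leaves every comparison at this position within the scatter.

Nothing available explains these numbers or bears on the result. The compounds shown leave open whether any group on this aromatic carbon can move the number beyond the scatter, for instance a primary amine, a carboxylic acid or a chain longer than hexyl. They also leave open whether a chain shorter than propyl, such as methyl, would differ from the chains compared here.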